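A chalcone analogue with a different aryl group

The source may hold more compounds than are shown below. What is called first, only, known or untested is meant among the compounds shown, and "the series" means these compounds.

Measured so far:
compound 1 `COc1cc(OC)c(OC)cc1/C=C/C(=O)c1ccc(OC)c2c1OC(C)(C)C=C2` gives > 10000 nM
compound 2 `COc1ccc(/C=C/C(=O)c2ccc(OC)c3c2OC(C)(C)C=C3)cn1` gives > 10000 nM

Both values come from a functional assay on HT-29 cells (Homo sapiens) for antiproliferative activity, read by MTT assay, with a stated time of 24 h; on this read-out higher numbers stand for weaker inhibition and lower numbers for stronger inhibition. For compound 1 the value > 10000 nM is a limit of the assay rather than a number. For compound 2 the value > 10000 nM is likewise a limit of the assay. Compound 2 therefore stands at the limit of > 10000 nM in this assay, at which 2 of the 2 values shown sit, so nothing separates it from compound 1 on these numbers.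

Compound 3 `COc1ccc(C(=O)/C=C/c2cc(Cl)ccc2O)c2c1C=CC(C)(C)O2` has not yet been tested. It differs from compound 2 in one place: 5-chloro-2-hydroxyphenyl in place of 6-methoxypyridin-3-yl on a double-bonded chain carbon bound to a double-bonded chain carbon. For the measured compounds named here, no step between two measured compounds is available, so nothing measured shows how this kind of change shifts the read-out. The step expected in this assay is a step that the limit leaves unreadable from compound 2 to compound 3, which is none beyond the scatter. Compound 3 is therefore expected to give about 15000 nM in this assay, within a range from 3000 nM to 60000 nM.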

Compound 3, half-maximal inhibitory concentration: 4970 nM
For compound 3 the middle estimate is 3.0-fold (0.48 log units) above the measured one; the range from low to high includes it.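

In this assay, for the compounds shown here, compound 3, with 5-chloro-2-hydroxyphenyl on a double-bonded chain carbon bound to a double-bonded chain carbon, gives 4970 nM as the first value here that is a number and not a limit. Putting this group in place of 6-methoxypyridin-3-yl brings an at least 2.0-fold lower number from compound 2 to compound 3 (0.30 log units; that floor lies within the scatter) on this read-out, so this position can hold a group that gives a readable value. The true size of the step stays unknown because its starting point is only a limit: the limit of > 10000 nM in this assay, at which 2 of the 3 values shown sit.

The chlorine and the hydroxyl enter together, so the compounds shown do not tell which of them matters, or whether both do. Also open, as far as these compounds go, is how the same position would read with an amine or a carboxylic acid on that ring in place of the chlorine.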